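The compounds below may be only part of what the source reports. "The series", "measured", "known", "first", "only" and "open" are said of these compounds alone.

Measured compounds:
- Compound 1, `NS(=O)(=O)Oc1ccc2c(c1)CN(C(=O)c1cccc(N3CCC(Cc4ccccc4)CC3)c1)CC2`: 41.9%
- Compound 2, `CCN(Cc1ccccn1)c1cccc(C(=O)N2CCc3ccc(OS(N)(=O)=O)cc3C2)c1`: 19.9%
- Compound 3, `CCN(Cc1cccnc1)c1ccc(C(=O)N2CCc3ccc(OS(N)(=O)=O)cc3C2)cc1`: 85.2%

All three share a core carrying the sulfamate group, and they differ in the amine-bearing ring attached to the amide. In an assay on HEK293 cells for inhibition of Steryl-sulfatase (Homo sapiens), tested at 1 uM (a lower number here means a weaker effect, a higher number a stronger effect of the compound at the concentration tested), compound 3 gives the highest of the three numbers. Its nearest neighbour is compound 1, whose number is lower by an amount beyond the usual scatter, and compound 2 stands furthest away, also beyond the scatter. No two of these compounds differ in only one place, so none of these gaps can be pinned to a single structural change.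

Compound 4, `CCN(Cc1ccncc1)c1ccc(C(=O)N2CCc3ccc(OS(N)(=O)=O)cc3C2)cc1`, has not yet been measured in this assay. It is built from the same atoms as compound 3, joined differently: pyridin-4-yl in place of pyridin-3-yl on a saturated chain carbon bound to a nitrogen on an aromatic ring

Among the compounds with values here, nothing among the measured compounds shows what moving the ring nitrogen in this way does. The expectation is therefore a small step, most likely a slight decrease, from compound 3 to compound 4 of a number 10.2 percentage points lower from compound 3 to compound 4 (beyond the scatter), and it may well fall within the scatter. For compound 4 the estimated inhibition in this assay is 75%, with a range from 45% to 95%.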

Compound 4, a percentage reported as inhibition, at one concentration (the size of the read-out at that concentration, not a potency): 86.6%
Compound 4: middle estimate off by 11.6 percentage points, on the low side; the measured number falls inside the stated range.
By their numbers in this assay, from the lowest: compound 2; then compound 1; then compounds 3 and 4 (each within the scatter of the next).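

Replacing pyridin-3-yl with pyridin-4-yl on a saturated chain carbon bound to a nitrogen on an aromatic ring gives, in this assay, a number 1.4 percentage points higher from compound 3 to compound 4 (within the scatter). Within the data shown here, this is the first direct comparison at this position, and it shows that this change of ring nitrogen position, with the same atoms and the same counted features, does not separate the two compounds at the single concentration tested. The read-out gives the size of the effect at that one concentration only, so any difference between them at other concentrations would not necessarily appear here, and no supporting data bear on why the swap leaves the two compounds indistinguishable.

As far as these compounds go, it remains open whether the ring nitrogen matters at all at this place, which a plain phenyl ring there, with no ring nitrogen, could test. Compound 2 carries pyridin-2-yl but differs from compound 3 in more than one place, so a pyridin-2-yl group on an otherwise identical compound would be needed to complete the comparison of ring nitrogen positions.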